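A Ketone in Place of the Ester-Bearing Side Chain

The source may hold more compounds than are shown below. What is called first, only, known or untested is meant among the compounds shown, and "the series" means these compounds.

Measured compounds: compound 1 `CCCOC(=O)C1=CCCCC1S(=O)(=O)Cc1ccc(F)cc1Cl`, 14 nM in a functional assay on RAW264.7 cells (Mus musculus), read by fluorescence; a higher number here means a weaker inhibitor, a lower number a stronger inhibitor; compound 2 `CC(C)OC(=O)C1=CCCCC1S(=O)(=O)Cc1ccc(F)cc1Cl`, 100 nM; compound 3 `CC(=O)OCC1=CCCCC1S(=O)(=O)Cc1ccc(F)cc1Cl`, > 10000 nM.

Compound 3 sits at a limit of this assay, (the limit of > 10000 nM in this assay, at which 1 of the 3 values shown sits), so only a bound is known for it. The steps to it were large: an at least 710-fold higher number from compound 1 to compound 3 (2.85 log units; beyond the scatter) and an at least 100-fold higher number from compound 2 to compound 3 (2.00 log units; beyond the scatter), whereas the ester-to-ester change was smaller, a 7.1-fold higher number from compound 1 to compound 2 (0.85 log units; beyond the scatter). Compound 4 `CCC(=O)C1=CCCCC1S(=O)(=O)Cc1ccc(F)cc1Cl` carries propanoyl in place of acetoxymethyl on a double-bonded ring carbon, restoring a carbonyl on that ring carbon as in compound 1 and compound 2. Compound 4 is therefore expected to fall well below the limit, with an estimated 100 nM (range 10 nM to 3000 nM). The expected step is an at least 100-fold lower number from compound 3 to compound 4 (2.00 log units; beyond the scatter), though a ketone is not an ester and the estimate is uncertain.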

Compound 4, half-maximal inhibitory concentration: 64 nM
Compound 4: middle estimate off by 1.6-fold (0.19 log units), on the high side; low and high end bracket the measured number.
By their numbers in this assay, from the lowest: compound 1; then compounds 4 and 2 (each within the scatter of the next). At a limit, above all of these: compound 3.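

In this assay, a carbonyl on this double-bonded ring carbon keeps a low number without an ester oxygen, as the change from acetoxymethyl to propanoyl gives an at least 150-fold lower number from compound 3 to compound 4 (2.19 log units; beyond the scatter). Compound 3 is held at a limit, not at a number: the limit of > 10000 nM in this assay, at which 1 of the 4 values shown sits.

Ethyl on the carbonyl carbon compares differently with the two esters, giving a 1.6-fold lower number from compound 2 to compound 4 (0.19 log units; within the scatter), but a 4.6-fold higher number from compound 1 to compound 4 (0.66 log units; beyond the scatter). On these data alone, whether an amide or a carboxylic acid on this ring carbon would behave like the ketone stays open, as does whether a longer chain on the ketone would close the step to compound 1.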